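From Trifluoromethyl to Fluoro in a Cytotoxicity Series

The compounds below may be only part of what the source reports. "The series", "measured", "known", "first", "only" and "open" are said of these compounds alone.

Compound 2 `O=C(CN1CCN(c2nnc(Cc3ccncc3)c3ccccc23)CC1)Nc1ccc(F)c(C(F)(F)F)c1` carries a pyridin-4-yl group on the saturated chain carbon bound to an aromatic carbon of the shared core, and in a functional assay on A549 cells (Homo sapiens) for cytotoxicity, read by MTT assay, with a stated time of 72 h (on this read-out lower numbers stand for stronger inhibition and higher numbers for weaker inhibition), compound 2 gives 16000 nM. Among the two compounds with a number, compound 2 stands at the higher end: its nearest neighbour, compound 1 `O=C(CN1CCN(c2nnc(Cc3ccccc3)c3ccccc23)CC1)Nc1ccc(F)c(C(F)(F)F)c1`, gives 2480 nM in this assay, and the only single-point step with a number, a 6.5-fold higher number from compound 1 to compound 2 (0.81 log units; beyond the scatter), separates the two. Compound 3 `Cc1ccccc1NC(=O)CN1CCN(c2nnc(Cc3ccccc3)c3ccccc23)CC1` differs from compound 1 in the group on the amide nitrogen; in this assay compound 3 is reported as "not active" (no number reported).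

Compound 4 `O=C(CN1CCN(c2nnc(Cc3ccncc3)c3ccccc23)CC1)Nc1ccc(F)c(F)c1` keeps the pyridin-4-yl group and alters the other end: fluoro in place of trifluoromethyl on an aromatic carbon. Among the compounds with values here, no measured step in this set concerns a change at that site; the one quantified step, from compound 1 to compound 2, was modest and lies elsewhere in the molecule. Within the data shown here, compound 3 shows only that a different group on the amide nitrogen left no measurable activity. Among the measured compounds shown here, with no direct precedent, the step is expected to be small to moderate, leaning toward a higher number, a 1.9-fold higher number from compound 2 to compound 4 (0.27 log units; within the scatter). Compound 4 is therefore estimated at 30000 nM in this assay, within 10000 nM to 90000 nM.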

Compound 4, half-maximal inhibitory concentration: 3790 nM
Beside the measured number, compound 4's estimate is 7.9-fold (0.90 log units) above it; measured number outside the range, below it.
By their numbers in this assay, from the lowest: compounds 1 and 4 (each within the scatter of the next); then compound 2.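

Replacing trifluoromethyl with fluoro, which turns 4-fluoro-3-(trifluoromethyl)phenyl into 3,4-difluorophenyl, gives a 4.2-fold lower number from compound 2 to compound 4 (0.63 log units; beyond the scatter) in this assay. Within the data shown here, this is the first number to bear on this position, and it shows that the read-out responds to the group there and that trifluoromethyl is not required for a measurable value when pyridin-4-yl is present. The step runs opposite in direction to a 6.5-fold higher number from compound 1 to compound 2 (0.81 log units; beyond the scatter), so a change at either end of the molecule can move the number, and in this series a change at this end can run against one at the other; no measurement available accounts for the size or direction of this step.

The compounds shown leave open whether fluoro in place of trifluoromethyl would move the number in the same direction in compound 1, which carries phenyl rather than pyridin-4-yl. They also leave open how chloro, methoxy or a nitrile at the same place on the ring would compare with fluoro and trifluoromethyl in this pyridin-4-yl series.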